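Compound 2 to compound 3: adding a fluoro group

This account rests on a few compounds, and the source may have more. Where it says the series, first, only, none or still open, it means among the compounds named here.

- compound 1 `O=C(NCCCCc1ccccc1)n1cc(-c2ccccc2)oc1=O`: < 1000 nM, a limit
- compound 2 `COc1cccc(-c2cn(C(=O)NCCCCc3ccccc3)c(=O)o2)c1`: < 1000 nM, a limit

In a physicochemical assay for solubility, read by HPLC, in phosphate buffer, measured as kinetic solubility, with a stated time of 1 h, at pH 7.4, tested at 250 uM (a lower number here means a less soluble compound, a higher number a more soluble compound), compound 2 gives only a limit, < 1000 nM, and no exact number. For the measured compounds named here, the one measured step is a step that the two limits leave unreadable from compound 1 to compound 2, so it gives no size to build on. The remaining guide is the limit of < 1000 nM in this assay, at which 2 of the 2 values shown sit.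

Compound 3 `COc1cc(-c2cn(C(=O)NCCCCc3ccccc3)c(=O)o2)ccc1F` differs from compound 2 by fluoro in place of hydrogen on an aromatic carbon, turning 3-methoxyphenyl into 4-fluoro-3-methoxyphenyl. No step beyond the scatter is expected in this assay, in either direction. The estimated step is a step that the limit leaves unreadable from compound 2 to compound 3. For compound 3 the expected value is 700 nM, with an estimated range of 300 nM to 1500 nM.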

Compound 3, solubility: < 1000 nM
Compound 3: only a limit was reported; the forecaster's own chance of this, stated with the estimate: 85%; the middle value does not contradict the limit.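

In this assay compound 3 gives < 1000 nM, a limit and not a number. The steps among compound 1, compound 2 and compound 3 cannot be read: the limit of < 1000 nM in this assay, at which 3 of the 3 values shown sit.

Whether the methoxy or fluoro group changes the true solubility of these compounds stays open.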